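Swapping fluoro for hydrogen on compound 2

A few compounds are considered here, and "the series" means these few. Any claim that something is new, unique, unknown or untested is made for them only; others in the source may bear on it.

In a physicochemical assay for lipophilicity, at pH 7.4 (a higher number here means a more lipophilic compound, a lower number a more polar compound), compound 1 `Cc1cc(Cl)c(C(=O)NC(=O)Nc2nc3ccc(S(=O)(=O)C4CCN(C)CC4)cc3s2)cc1-n1cccn1` gives 2.5 and compound 2 `CN1CCC(S(=O)(=O)c2ccc3nc(NC(=O)NC(=O)c4cc(-n5cccn5)c(F)cc4Cl)sc3c2)CC1` gives 2.4. These two numbers lie within the usual scatter of each other, so compound 2 cannot be told apart from compound 1 on this evidence. The next structure, compound 3 `CN1CCC(S(=O)(=O)c2ccc3nc(NC(=O)NC(=O)c4cc(-n5cccn5)ccc4Cl)sc3c2)CC1`, has hydrogen in place of fluoro on an aromatic carbon. Among the compounds with values here, only one measured step bears on this change. It sits on the same aromatic carbon, with fluoro in place of methyl, and the read-out there is a number 0.10 log units lower from compound 1 to compound 2 (within the scatter). Within the data shown here, that is a single step, and no measurement yet shows what hydrogen does on this carbon. On the strength of that step, which ends at compound 2, the change to compound 3 is expected to stay within the scatter in this assay, with no real shift in either direction. The expected step is a number 0.10 log units lower from compound 2 to compound 3 (within the scatter). The estimate for compound 3 is 2.3, with an expected range from 2 to 2.6.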

Compound 3, distribution coefficient: 2.3
For compound 3 middle estimate and measured number coincide at the digits printed; low and high end bracket the measured number.
By their numbers in this assay, from the lowest: compounds 3, 2 and 1 (each within the scatter of the next).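

With hydrogen on this aromatic carbon, ortho to a 1H-pyrazol-1-yl group, meta to a chloro group and para to a large group, the position has now been seen with methyl, fluoro and hydrogen, and in this assay the swap of fluoro for hydrogen gives a number 0.10 log units lower from compound 2 to compound 3 (within the scatter). The direct comparison of hydrogen with methyl, which the earlier compounds could not offer, gives a number 0.20 log units lower from compound 1 to compound 3 (within the scatter), so none of the listed steps at this carbon separates its substituents, and on the shared core of these compounds the three can't be told apart in this read-out. Nothing among the available findings offers an explanation for this result.

What the compounds leave open is whether a group of another kind on this same carbon, such as an amine, a carboxylic acid or a longer chain, would give a step beyond the scatter in this assay. They also leave open whether the same swaps of methyl, fluoro and hydrogen would read the same way on any other carbon of this six-membered aromatic ring.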